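This account rests on a few compounds, and the source may have more. Where it says the series, first, only, none or still open, it means among the compounds named here.

Measured compounds in an assay on isolated protein (Cavia porcellus) with Sigma non-opioid intracellular receptor 1 (Homo sapiens) as the target, read by radioligand binding; on this read-out lower numbers stand for stronger inhibition and higher numbers for weaker inhibition:
compound 1 `O=c1cc(-c2ccccc2)oc2ccc(OCCCCCCN3CCC(O)CC3)cc12` gives 121 nM
compound 2 `O=c1cc(-c2cccs2)oc2ccc(OCCCCCCN3CCC(O)CC3)cc12` gives 232 nM
compound 3 `O=c1cc(-c2ccc(F)cc2)oc2ccc(OCCCCCCN3CCC(O)CC3)cc12` gives 132 nM

Compound 3 sits at the second highest of the three numbers, nearest to compound 1 and furthest from compound 2; all three values lie within the scatter of one another, so no order among them can be read. Compound 4 `O=c1cc(-c2ccncc2)oc2ccc(OCCCCCCN3CCC(O)CC3)cc12` is not yet measured. The change from compound 3 is pyridin-4-yl in place of 4-fluorophenyl on an aromatic carbon. Three measured steps vary this same aryl group: a 1.1-fold higher number from compound 1 to compound 3 (0.04 log units; within the scatter); a 1.8-fold lower number from compound 2 to compound 3 (0.24 log units; within the scatter); a 1.9-fold higher number from compound 1 to compound 2 (0.28 log units; within the scatter). Each of these lies within the scatter, including the switch between phenyl and thiophen-2-yl. Going by the values given here, none of them places a nitrogen in the aryl ring as pyridin-4-yl does, so the new change has no direct precedent in this set, and the only guide is that aryl variation so far has not moved the numbers. The step from compound 3 to compound 4 is therefore expected to be a 1.5-fold higher number from compound 3 to compound 4 (0.18 log units; within the scatter) in this assay, small and not beyond the scatter, with a wider range allowed for the untested ring nitrogen. Compound 4 is estimated at 200 nM in this assay, between 80 nM and 500 nM.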

Compound 4, half-maximal inhibitory concentration: 308 nM
Estimate against measurement, compound 4: 1.5-fold (0.19 log units) below; measured number inside the range.
By their numbers in this assay, from the lowest: compounds 1, 3, 2 and 4 (each within the scatter of the next, the first and the last beyond it).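

In this assay, going by these compounds alone, pyridin-4-yl is the first group on this aromatic carbon, next to the ring oxygen, to give steps beyond the scatter: (a 2.3-fold higher number from compound 3 to compound 4 (0.37 log units; beyond the scatter)) and (a 2.5-fold higher number from compound 1 to compound 4 (0.41 log units; beyond the scatter)), both modest, so this position is not indifferent to the choice of aryl group, as the earlier compounds alone might have suggested. The pattern is not a clean split between pyridin-4-yl and the other aryl groups, since compound 2 goes against it: its thiophen-2-yl stays within the scatter of pyridin-4-yl (a 1.3-fold higher number from compound 2 to compound 4 (0.12 log units; within the scatter)), and it is also within the scatter of phenyl and 4-fluorophenyl. No measurement at hand bears on the origin of these steps.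

The compounds shown leave open whether the step depends on having a ring nitrogen at all or on where that nitrogen sits, a question that pyridin-3-yl or pyridin-2-yl in the same place could address. They also leave open how this position responds to a phenyl ring carrying an amine or a carboxylic acid.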